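Swapping the aryl tail of a sulfonamide piperidine

This account rests on a few compounds, and the source may have more. Where it says the series, first, only, none or still open, it means among the compounds named here.

The measured compounds, with their values in a functional assay on DLD-1 cells (Homo sapiens) for antiproliferative activity, read by CellTiter-Glo, with a stated time of 72 h (on this read-out higher numbers stand for weaker inhibition and lower numbers for stronger inhibition), are:
compound 1, `CC1CCN(C2CCN(S(=O)(=O)c3cccc(-c4ccccc4C(F)(F)F)c3)CC2)CC1`, 10 nM
compound 2, `Cc1cc(C)c(S(=O)(=O)N2CCC(C3OCC(C)CO3)CC2)c(C)c1`, > 5000 nM
compound 3, `Cc1ccc(-c2ccccc2S(=O)(=O)N2CCC(N3CCC(C)CC3)CC2)cc1`, 366 nM

Compound 1 stands lowest of the two numbers in this assay. Its nearest neighbour is compound 3, whose value sits well above it, a gap beyond the usual scatter. For compound 2 the value of > 5000 nM is a limit of this assay rather than a number.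

The step under consideration leads from compound 1 to compound 4, `Cc1ccc(-c2cccc(S(=O)(=O)N3CCC(N4CCC(C)CC4)CC3)c2)cc1`. The change is 4-methylphenyl in place of 2-(trifluoromethyl)phenyl on an aromatic carbon. Within the data shown here, no step between measured compounds of this kind is available, so nothing directly shows how this assay responds to it. The estimate for compound 4 therefore rests on compound 1 alone, whose value of 10 nM is the anchor, and the expected step of a 4.0-fold higher number from compound 1 to compound 4 (0.60 log units; beyond the scatter) is a moderate move toward weaker inhibition, with wide uncertainty. Compound 4 is thus expected to give about 40 nM, between 10 nM and 250 nM.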

Compound 4, half-maximal inhibitory concentration: 11 nM
Estimate against measurement, compound 4: 3.6-fold (0.56 log units) above; low and high end bracket the measured number.
By their numbers in this assay, from the lowest: compounds 1 and 4 (each within the scatter of the next); then compound 3. At a limit, above all of these: compound 2.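

Among these compounds, replacing 2-(trifluoromethyl)phenyl with 4-methylphenyl on this aromatic carbon gives a 1.1-fold higher number from compound 1 to compound 4 (0.04 log units; within the scatter) in this assay and provides the first direct reading of a change at this position. The assay does not separate these two aryl groups, so this position accepts either one without a change beyond the scatter, even though the fluorine atoms are gone and the substituent sits elsewhere on the ring. Nothing shown here offers a measured reason why the two tails match.

The compounds shown leave open how this assay responds to an aryl tail bearing an amine or a carboxylic acid, or to a pyridine ring in place of the phenyl ring. They also leave open whether the tail needs any substituent at all, a question an unsubstituted phenyl group would answer.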